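A few compounds are considered here, and "the series" means these few. Any claim that something is new, unique, unknown or untested is made for them only; others in the source may bear on it.

Measured so far in an assay on HEK293 cells for inhibition of Voltage-dependent T-type calcium channel subunit alpha-1G (Homo sapiens), read by patch clamp, tested at 10 uM; a higher number here means more inhibition at the concentration tested (going by the name of the read-out), a lower number less inhibition:
compound 1 `COc1ccccc1N1CCN(C[C@@H](O)COc2ccc(F)cc2)CC1` gives 50.7%
compound 2 `O[C@@H](COc1ccc(F)cc1)CN1CCN(c2ccc(F)cc2)CC1` gives 47.5%

For the measured compounds named here, compound 1 stands highest of the two numbers, but only narrowly: its one neighbour is compound 2, and the step of a number 3.2 percentage points lower from compound 1 to compound 2 (within the scatter) is within the scatter, so the two cannot be ordered on inhibition in this assay. Compound 3 `COc1ccccc1N1CCN(C[C@H](O)COc2ccc(F)cc2)CC1` remains to be measured. (the two compounds have the same atoms and bonds and differ only in configuration as drawn: 1 of 1 stereo elements differ; a stereocentre at a saturated chain carbon is drawn R in compound 1 and S in compound 3). Going by the values given here, the single measured step, a number 3.2 percentage points lower from compound 1 to compound 2 (within the scatter), concerns a change of ring substituent on the piperazine nitrogen and says nothing about inversion of a stereocentre; no measured pair here differs in configuration. Among the compounds with values here, there is therefore no direction to read from the data, and the scatter of the assay is the only guide to how small a step might be. Compound 3 is expected, on that basis, to lie near compound 1, with a step of a number 5.7 percentage points lower from compound 1 to compound 3 (within the scatter) from compound 1 to compound 3 that is set close to zero. The estimate for compound 3 in this assay is 45%, within a broad range from 20% to 70%, the width reflecting that an enantiomer pair has not been tested.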

Compound 3, a percentage reported as inhibition, at one concentration (the size of the read-out at that concentration, not a potency): 41%
Estimate against measurement, compound 3: 4 percentage points above; the measured number falls inside the stated range.
By their numbers in this assay, from the lowest: compounds 3, 2 and 1 (each within the scatter of the next).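

For the compounds shown here, compound 3 brings the first change of configuration into the set, and in this assay inverting the stereocentre at a saturated chain carbon from R to S gives a number 9.7 percentage points lower from compound 1 to compound 3 (within the scatter). The two compounds therefore cannot be ordered on inhibition in this assay, so the drawn configuration at this position has no readable effect on the number at the one concentration tested. The comparison is also a clean one, with only a single structural difference to consider: the fact that compounds 1 and 3 differ only in the configuration as drawn

The compounds leave open whether the inversion would read the same way with 4-fluorophenyl in place of 2-methoxyphenyl on the amine nitrogen in the ring, as in compound 2, and whether a difference in potency between compound 1 and compound 3 would appear beyond this single-concentration read-out. Also open is how an amine or a longer chain at the saturated chain carbon would read in this assay, since neither group appears among these compounds.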